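The compounds below may be only part of what the source reports. "The series", "measured", "known", "first", "only" and "open" are said of these compounds alone.

Working notes on the chalcone-amide series and its tolerability readout.

Compound 1 `CCOc1ccc(C(=O)/C=C/c2ccc(C(=O)Nc3cccc(-c4cc(C(=O)OC)no4)c3)cc2)cc1` is the reference point of this set. In an ADME assay on Vero cells (Chlorocebus sabaeus) for cytotoxicity, read by MTT assay, with a stated time of 72 h (on this read-out higher numbers stand for lower toxicity in this test and lower numbers for higher toxicity in this test), compound 1 gives > 40 ug/mL, which is a limit of the assay and not a measured number. Among the three entries shown, compound 1 sits at the limit of > 40 ug/mL in this assay, at which 1 of the 3 values shown sits. Compound 2 `CCOC(=O)c1cc(-c2cccc(NC(=O)c3cccc(C(F)(F)F)c3)c2)on1` carries the trifluoromethyl amide instead of the chalcone arm; in this assay compound 2 gives "not determined" (no result reported), so it adds nothing to the picture. Compound 3 `CCOC(=O)c1cc(-c2cccc(NC(=O)c3ccc(/C=C/C(=O)c4ccc(Cl)cc4)cc3)c2)on1` keeps the chalcone arm with a chloro-substituted ring and the ethyl ester on the core; in this assay compound 3 gives > 80 ug/mL, again a limit of the assay rather than a number, and it stands at the limit of > 80 ug/mL in this assay, at which 1 of the 3 values shown sits. Within the data shown here, no step between two fully measured compounds exists here, so the series shows only that the two chalcone amides reached the assay ceiling without a readable value.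

Compound 4 `COC(=O)c1cc(-c2cccc(NC(=O)c3ccc(/C=C/C(=O)c4ccc(CC(C)C)cc4)cc3)c2)on1` differs from compound 1 in one place: isobutyl in place of ethoxy on an aromatic carbon. With both neighbours at limits, the expected step from compound 1 to compound 4 is estimated as none beyond the scatter, a number no higher from compound 1 to compound 4 (the limit leaves the size open). For compound 4 the estimate in this assay is 40 ug/mL, expected within 20 ug/mL to 80 ug/mL, with a real chance that only a limit is reported.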

Compound 4, half-maximal cytotoxic concentration: > 10 ug/mL
Compound 4 was reported as a limit; the forecaster's own chance of this, stated with the estimate: 60%; the middle value does not contradict the limit.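

In this assay compound 4 gives > 10 ug/mL, which is a limit of the assay and not a number. Among these compounds, compound 1 is also reported only as a limit, so no step from compound 1 to compound 4 can be read. The compounds shown leave open what isobutyl in place of ethoxy does to this read-out.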